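Amino in place of chloro, second instance in the series

A few compounds are considered here, and "the series" means these few. Any claim that something is new, unique, unknown or untested is made for them only; others in the source may bear on it.

Measured so far:
compound 1 `Nc1nc(Cl)c2ncn(Cc3ccc(CCl)cc3)c2n1` — 6920 nM
compound 2 `ClCc1cccc(Cn2cnc3c(Cl)nc(Cl)nc32)c1` — 2290 nM
compound 3 `ClCc1ccc(Cn2cnc3c(Cl)nc(Cl)nc32)cc1` — 2190 nM

All three values come from a functional assay on HOP-62 cells (Homo sapiens) for cytotoxicity, read by sulforhodamine B assay, with a stated time of 48 h; on this read-out lower numbers stand for stronger inhibition of growth and higher numbers for weaker inhibition of growth. Compound 2 and compound 3 share the same atoms joined differently; the difference between the two cores is not broken down here, and their values in this assay lie within the scatter of each other, so no order between them is claimed. Compound 1 derives from compound 3 by one change, (amino in place of chloro on an aromatic carbon), and this gives a 3.2-fold higher number from compound 3 to compound 1 (0.50 log units; beyond the scatter).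

Compound 4 `Nc1nc(Cl)c2ncn(Cc3cccc(CCl)c3)c2n1` has not yet been measured. It derives from compound 2 by amino in place of chloro on an aromatic carbon, which is the same change as that from compound 3 to compound 1. Because the earlier instance gave a 3.2-fold higher number from compound 3 to compound 1 (0.50 log units; beyond the scatter), a step of similar size is expected here, estimated as a 3.1-fold higher number from compound 2 to compound 4 (0.49 log units; beyond the scatter). On that basis compound 4 is expected to give about 7000 nM in this assay, with a range estimated from 3500 nM to 14000 nM; this rests on one prior step only.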

Compound 4, concentration for 50% growth inhibition: 5750 nM
For compound 4 the middle estimate is 1.2-fold (0.09 log units) above the measured one; low and high end bracket the measured number.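

In this assay, amino in place of chloro on an aromatic carbon gives a 2.5-fold higher number from compound 2 to compound 4 (0.40 log units; beyond the scatter). Set beside the earlier instance, the step keeps its direction and shows no difference in size on the second core: the same change on two cores in this assay, a 3.2-fold higher number (0.50 log units; beyond the scatter) from compound 3 to compound 1 and a 2.5-fold higher number (0.40 log units; beyond the scatter) from compound 2 to compound 4, 1.3-fold (0.10 log units) apart, within the scatter of two such steps

This supports carrying the change across these two cores, whose atoms are the same but joined differently, and in this one assay a higher number can be expected from it on either core; it does not show why the number rises, and two steps on closely related cores say nothing about how the change would behave on a more distant core or in other cells.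

The compounds shown leave open whether a different group on that carbon, such as methylamino, dimethylamino or methoxy, would move the number in the same way as amino. Also open, going by these compounds, is how the step would behave if the chloromethyl group gave way to a hydroxymethyl group or a longer chain.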